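The source may report more compounds than this note shows. Statements on the series, on what has been measured and on what is new or still open speak of the compounds shown alone.

In a functional assay on DLD-1 cells (Homo sapiens) for cytotoxicity, read by MTT assay, with a stated time of 72 h (on this read-out lower numbers stand for stronger inhibition and higher numbers for weaker inhibition), the measured compounds stand as follows:

Compound 1 `CN1C/C(=C\c2ccccc2F)C(=O)/C(=C/c2ccccc2F)C1` gives 810 nM
Compound 2 `CN1C/C(=C\c2cc(F)c(F)cc2F)C(=O)/C(=C/c2cc(F)c(F)cc2F)C1` gives 1800 nM
Compound 3 `CCN1C/C(=C\c2cc(F)cc(F)c2)C(=O)/C(=C/c2cc(F)cc(F)c2)C1` gives 640 nM

Compound 2, at 1800 nM, has the highest number of the three and is therefore the weakest inhibitor so far. Its distance from both compound 1 and compound 3 lies beyond the scatter, though only modestly so in the case of compound 1.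

Compound 4 `CCN1C/C(=C\c2cc(F)c(F)cc2F)C(=O)/C(=C/c2cc(F)c(F)cc2F)C1` keeps the fluorinated aryl groups of compound 2 and differs by a single change (methyl in place of hydrogen on a saturated chain carbon bound to an amine nitrogen in a ring) on a saturated chain carbon bound to an amine nitrogen in a ring, so that methyl becomes ethyl. Among the measured compounds shown here, no pair of measured compounds isolates this change, which leaves the expectation on thin ground. Compound 3 also carries the ethyl group and gives 640 nM in this assay, but its aryl groups differ from those of compound 4, so its value offers only indirect guidance.

The step of a 1.4-fold lower number from compound 2 to compound 4 (0.14 log units; within the scatter) is expected to stay within the scatter, leaning slightly toward a lower number if it moves at all. For compound 4 the estimated value is 1300 nM (expected range 600 nM to 2800 nM).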

Compound 4, half-maximal inhibitory concentration: 520 nM
For compound 4 the middle estimate is 2.5-fold (0.40 log units) above the measured one, outside the stated range (below it).
By their numbers in this assay, from the lowest: compounds 4, 3 and 1 (each within the scatter of the next); then compound 2.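

In this assay, among the compounds shown here, compound 2 and compound 4 form the first pair that differ in one place only, and so the first to isolate the change on a saturated chain carbon bound to an amine nitrogen in a ring. Methyl in place of hydrogen there, which cut one bond further out reads as methyl to ethyl, gives a 3.5-fold lower number from compound 2 to compound 4 (0.54 log units; beyond the scatter) and so a modest step beyond the scatter, showing that with the fluorinated aryl groups held constant, this position is not silent and a single added carbon moves the number toward stronger inhibition. Nothing at hand accounts for the step, which stands as an observation on this one pair.

The compounds shown do not tell whether a longer chain such as propyl, or a ring such as cyclopropyl, in this place would carry the trend further, hold it or reverse it. They also leave open whether methyl to ethyl gives a step of similar size with the aryl groups of compound 1 or compound 3, since each of these stands here without a partner differing only in that place.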